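The source may report more compounds than this note shows. Statements on the series, on what has been measured and on what is new or still open speak of the compounds shown alone.

Working notes on the series. Two compounds carry numbers in a functional assay on IGROV-1 cells (Homo sapiens) for cytotoxicity, read by sulforhodamine B assay, with a stated time of 48 h; a higher number here means a weaker inhibitor of growth, a lower number a stronger inhibitor of growth. Compound 1 `ClCc1ccc(Cn2cnc3c(Cl)ncnc32)cc1` gives 25100 nM in this assay. Compound 2 `ClCc1ccccc1Cn1cnc2c(Cl)nc(Cl)nc21` gives 3310 nM in this assay, the lowest of the two numbers, with compound 1 as the nearest and higher value, beyond the scatter.

Compound 3 `ClCc1ccccc1Cn1cnc2c(Cl)ncnc21` is not yet measured in this assay. It differs from compound 2 in one place: hydrogen in place of chloro on an aromatic carbon, at the position between two ring nitrogen atoms of the fused core. Going by the values given here, no pair among the measured compounds shows this change alone, so the size of the step is open; compound 1 and compound 2 differ in two places at once and do not separate them.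

The expected step from compound 2 to compound 3 is a 2.4-fold higher number from compound 2 to compound 3 (0.38 log units; beyond the scatter), towards a weaker inhibitor, of modest size and possibly within the scatter. Compound 3 is estimated at 8000 nM, with a range from 2000 nM to 30000 nM.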

Compound 3, concentration for total growth inhibition: 8910 nM
Compound 3: middle estimate off by 1.1-fold (0.05 log units), on the low side; the measured number falls inside the stated range.
By their numbers in this assay, from the lowest: compound 2; then compound 3; then compound 1.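

Replacing the chloro group with hydrogen on the aromatic carbon between two ring nitrogen atoms now has a reading of its own, free of any other change: in this assay it gives a weaker inhibitor of growth (a 2.7-fold higher number from compound 2 to compound 3 (0.43 log units; beyond the scatter)). The step is modest but beyond the scatter, so the chloro group at this position is linked to a stronger inhibitor of growth in this pair, though a single pair shows no trend. No accompanying measurement bears on the origin of this step.

Still open, from the compounds shown here alone, is whether an amine or a methoxy group at this position would match chloro, fall to the level of hydrogen, or go beyond either. Also open, going by these compounds, is whether the step keeps its size with the other arrangement of the chloromethyl group seen in compound 1.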